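Replacing 4-chlorophenyl with (1H-benzimidazol-2-yl)methyl

This account rests on a few compounds, and the source may have more. Where it says the series, first, only, none or still open, it means among the compounds named here.

In a functional assay on A549 cells (Homo sapiens) for cytotoxicity, read by resazurin assay, with a stated time of 72 h (on this read-out lower numbers stand for stronger inhibition and higher numbers for weaker inhibition), compound 3 (`Nc1c(-c2nc3ccccc3[nH]2)cc(-c2ccccc2)n1-c1ccc(Cl)cc1`) gives 9900 nM, the highest of three numbers, although a 1.4-fold higher number from compound 2 to compound 3 (0.15 log units; within the scatter) separates it only within the scatter from compound 2 (`Nc1c(-c2nc3ccccc3[nH]2)cc(-c2ccccc2)n1-c1cccc(Cl)c1`), at 7000 nM. Compound 1 (`Nc1c(-c2nc3ccccc3[nH]2)cc(-c2ccccc2)n1-c1ccncc1`) gives 1100 nM. Compound 4 (`Nc1c(-c2nc3ccccc3[nH]2)cc(-c2ccccc2)n1Cc1nc2ccccc2[nH]1`) carries (1H-benzimidazol-2-yl)methyl in place of 4-chlorophenyl on the aromatic nitrogen: (1H-benzimidazol-2-yl)methyl in place of 4-chlorophenyl on an aromatic nitrogen. The measured steps at this nitrogen are modest: a 6.4-fold higher number from compound 1 to compound 2 (0.80 log units; beyond the scatter) and a 9.0-fold higher number from compound 1 to compound 3 (0.95 log units; beyond the scatter). Going by the values given here, both lead away from the nitrogen-containing pyridin-4-yl, but no measured compound has the entering group, so the guide is weak. A lower number is expected, with a 2.8-fold lower number from compound 3 to compound 4 (0.45 log units; beyond the scatter) as the estimated modest step. The estimate for compound 4 is 3500 nM, within an expected range of 900 nM to 12000 nM.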

Compound 4, half-maximal inhibitory concentration: 5100 nM
The estimate for compound 4 lay 1.5-fold (0.16 log units) below the measured number; the measured number falls inside the stated range.
By their numbers in this assay, from the lowest: compound 1; then compounds 4, 2 and 3 (each within the scatter of the next).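

In this assay, (1H-benzimidazol-2-yl)methyl on this nitrogen cannot be told apart from either chlorophenyl group, with a 1.9-fold lower number from compound 3 to compound 4 (0.29 log units; within the scatter) and a 1.4-fold lower number from compound 2 to compound 4 (0.14 log units; within the scatter). Compound 1 remains separate from this larger group too, with a 4.6-fold higher number from compound 1 to compound 4 (0.67 log units; beyond the scatter), so pyridin-4-yl keeps the lowest number of the four compounds. Nothing available accounts for this result. Open, as far as these compounds go, is whether a benzyl group, which would keep the methyl link without the benzimidazole, would give a similar number. Also open, from the compounds shown here alone, is how a pyridin-3-yl group or a longer chain ending in an amine would compare with pyridin-4-yl.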